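The compounds below may be only part of what the source reports. "The series", "measured", "known", "first", "only" and "open" are said of these compounds alone.

Measured so far in a functional assay on HeLa cells (Homo sapiens) for antiproliferative activity, read by CCK-8 assay, with a stated time of 72 h; a lower number here means a stronger inhibitor, a higher number a weaker inhibitor:
compound 1 `Cc1ccc(C(=O)Nc2cccc(-c3oc4cc(-c5ccc(F)cc5)ccc4c(=O)c3O)c2)cc1`: 6190 nM
compound 2 `O=C(Nc1cccc(-c2oc3cc(-c4ccc(F)cc4)ccc3c(=O)c2O)c1)c1cccc(F)c1`: 8780 nM

Compound 2 stands alongside compound 1, the two separated only by a 1.4-fold higher number from compound 1 to compound 2 (0.15 log units; within the scatter), a swap of the aryl group on the carbonyl carbon that stays within the scatter. Compound 3 `O=C(Nc1cccc(-c2oc3cc(-c4ccc(F)cc4)ccc3c(=O)c2O)c1)c1ccc([N+](=O)[O-])cc1` differs from compound 2 by 4-nitrophenyl in place of 3-fluorophenyl on a carbonyl carbon. Among the measured compounds shown here, the one measured step bears on this as the same kind of swap at the same place, and it was small, so no step beyond the scatter is expected from compound 2 to compound 3 in this assay. The estimate for compound 3 is 8000 nM, within 3000 nM to 25000 nM. The expected step is a 1.1-fold lower number from compound 2 to compound 3 (0.04 log units; within the scatter).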

Compound 3, half-maximal inhibitory concentration: 12300 nM
The estimate for compound 3 lay 1.5-fold (0.19 log units) below the measured number, within the range that was stated.
By their numbers in this assay, from the lowest: compounds 1, 2 and 3 (each within the scatter of the next).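

In this assay, 4-nitrophenyl in place of 3-fluorophenyl on a carbonyl carbon gives a 1.4-fold higher number from compound 2 to compound 3 (0.15 log units; within the scatter) and thus adds a third aryl group at this place without a step beyond the scatter. Nitro in place of methyl on an aromatic carbon gives a 2.0-fold higher number from compound 1 to compound 3 (0.30 log units; within the scatter) and so also stays within the scatter, leaving the series flat across all three aryl groups. Nothing available explains this flatness.

Open, going by these compounds, is whether an aryl ring bearing an amine or a carboxylic acid, or a cyclohexyl group or longer alkyl chain in place of the ring, would give a step beyond the scatter.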